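The source may report more compounds than this note shows. Statements on the series, on what has been measured and on what is new or still open speak of the compounds shown alone.

Compound 2 `O=C(Nc1cccc(-n2cc(-c3ccncc3)c(-c3ccc(Cl)c(O)c3)n2)c1)Nc1cc(C(F)(F)F)cc(C(F)(F)F)c1` gives 1750 nM in a functional assay on HOP-92 cells (Homo sapiens) for inhibition, read by sulforhodamine B assay, with a stated time of 48 h; a lower number here means a stronger inhibitor of growth, a higher number a weaker inhibitor of growth. Within the data shown here, of the three numbers available, the one for compound 2 is the lowest, but compound 1 `O=C(Nc1cccc(-n2cc(-c3ccncc3)c(-c3ccc(Cl)c(O)c3)n2)c1)Nc1ccc(Cl)c(Cl)c1`, which in this assay gives 1910 nM, sits within the scatter of it, so no order between these two can be drawn. Compound 3 `COc1cc(-c2nn(-c3cccc(NC(=O)c4ccccc4)c3)cc2-c2ccncc2)ccc1Cl` gives 4710 nM in this assay, and that gap to compound 2 is beyond the scatter; compound 3 also differs from compound 2 in more than one place, so the gap is not assigned to any single change.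

Compound 4 `O=C(Nc1cccc(-n2cc(-c3ccncc3)c(-c3ccc(Cl)c(O)c3)n2)c1)Nc1cccc(C(F)(F)F)c1` is not yet measured. It differs from compound 2 in one place: hydrogen in place of trifluoromethyl on an aromatic carbon. Among the measured compounds shown here, no pair of measured compounds differing in one place is available, so the size of this step has no precedent. The expectation is that the step of a 1.3-fold higher number from compound 2 to compound 4 (0.10 log units; within the scatter) stays within the scatter, with a slight lean toward a higher number. Compound 4 is expected to give 2200 nM in this assay, with a range from 1100 nM to 4500 nM.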

Compound 4, concentration for total growth inhibition: 2230 nM
Estimate against measurement, compound 4: 1.0-fold (0.01 log units) below; the range from low to high includes it.
By their numbers in this assay, from the lowest: compounds 2, 1 and 4 (each within the scatter of the next); then compound 3.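

In this assay, among these compounds, hydrogen in place of trifluoromethyl on this aromatic carbon gives a 1.3-fold higher number from compound 2 to compound 4 (0.11 log units; within the scatter), the first one-place step, and it shows that a single trifluoromethyl group on this ring reads the same as two within the scatter. 3-(Trifluoromethyl)phenyl in place of 3,4-dichlorophenyl on the amide-type nitrogen gives a 1.2-fold higher number from compound 1 to compound 4 (0.07 log units; within the scatter), so the three ring patterns of compounds 1, 2 and 4 cannot be separated in this assay. No measurement at hand accounts for this flat response.

The compounds shown leave open whether an unsubstituted phenyl ring, an amine or a carboxylic acid at this end of the molecule would move the number beyond the scatter. From the compounds shown here alone, compound 3 differs from these compounds in more than one place, so what sets its number apart also stays open.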